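A few compounds are considered here, and "the series" means these few. Any claim that something is new, unique, unknown or untested is made for them only; others in the source may bear on it.

In a functional assay on cells (Macrophage, Homo sapiens) for cytotoxicity (a higher number here means that more compound is tolerated, a lower number that less compound is tolerated), compound 1 `Cc1cc(C)cc(S(=O)(=O)c2c(C(=O)NN3CCOC3=O)[nH]c3ccc(Cl)cc23)c1` gives > 100 uM, which is a limit and not a number. Compound 2 `Cc1cc(C)cc(S(=O)(=O)c2c(C(=O)NNC(C)C)[nH]c3ccc(Cl)cc23)c1` gives > 100 uM, again a limit and not a number. Among the measured compounds shown here, compound 2 therefore has no exact place on the scale, and the only other value shown is a limit too: the data show (the limit of > 100 uM in this assay, at which 2 of the 2 values shown sit). The next change leads to compound 3 `Cc1cc(C)cc(S(=O)(=O)c2c(C(=O)NNC3CCCCC3)[nH]c3ccc(Cl)cc23)c1`, with cyclohexyl in place of isopropyl on an amine nitrogen. For the measured compounds named here, the one measured step that bears on this is a step that the two limits leave unreadable from compound 1 to compound 2, with isopropylamino in place of 2-oxo-1,3-oxazolidin-3-yl on an amide-type nitrogen. That step offers no size to carry over, so no step beyond the scatter is expected in this assay, in either direction. The expected step is a number no higher from compound 2 to compound 3 (the limit leaves the size open). Compound 3 is estimated at 100 uM, with an expected range from 40 uM to 200 uM.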

Compound 3, half-maximal toxic concentration: > 100 uM
Compound 3 was reported as a limit; the forecaster's own chance of this, stated with the estimate: 65%; the middle value sits exactly at the limit.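

Compound 1, compound 2 and compound 3 all sit at the same limit, which is not a number, so no step between them can be read: the limit of > 100 uM in this assay, at which 3 of the 3 values shown sit.

Still open, as far as these compounds go, is the concentration at which each compound becomes toxic in this assay, and whether exchanging these groups changes it.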